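Swapping a Triazole Ester for a Benzamide on a Shared Core

This account rests on a few compounds, and the source may have more. Where it says the series, first, only, none or still open, it means among the compounds named here.

Compound 1, `NS(=O)(=O)c1cc(-c2nnc(CN3CCN(c4ccc(Cl)cc4)CC3)o2)c(Cl)cc1SCc1ccccc1`: 11000 nM
Compound 2, `CCOC(=O)c1cn(Cc2nnc(-c3cc(S(N)(=O)=O)c(SCc4ccccc4)cc3Cl)o2)nn1`: 122000 nM

Of the compounds shown here, two have been measured in a functional assay on HeLa cells (Homo sapiens) for cytotoxicity, read by MTT assay, with a stated time of 72 h; a higher number here means a weaker inhibitor, a lower number a stronger inhibitor. Compound 1 `NS(=O)(=O)c1cc(-c2nnc(CN3CCN(c4ccc(Cl)cc4)CC3)o2)c(Cl)cc1SCc1ccccc1` gives 11000 nM. Compound 2 `CCOC(=O)c1cn(Cc2nnc(-c3cc(S(N)(=O)=O)c(SCc4ccccc4)cc3Cl)o2)nn1` gives 122000 nM, the higher of the two numbers, so compound 2 is the weaker inhibitor of the pair. The two differ in more than one place, so only their values can be set side by side.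

Compound 3 `NS(=O)(=O)c1cc(-c2nnc(CNC(=O)c3ccccc3)o2)c(Cl)cc1SCc1ccccc1` has not been measured. It differs from compound 2 in one place: benzamido in place of 4-(ethoxycarbonyl)-1H-1,2,3-triazol-1-yl on a saturated chain carbon bound to an aromatic carbon. Within the data shown here, no measured pair shows this change, so there is no step to copy. Compound 1, which shares the core but carries a different group in place of the triazole, gives 11000 nM, so other groups there are compatible with a lower number. The step of a 4.1-fold lower number from compound 2 to compound 3 (0.61 log units; beyond the scatter) is expected to go toward a lower number, beyond the scatter. For compound 3 in this assay the estimate is 30000 nM, ranging from 8000 nM to 120000 nM.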

Compound 3, half-maximal inhibitory concentration: 105000 nM
For compound 3 the middle estimate is 3.5-fold (0.54 log units) below the measured one; the measured number falls inside the stated range.
By their numbers in this assay, from the lowest: compound 1; then compounds 3 and 2 (each within the scatter of the next).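

In this assay, exchanging the two groups gives a 1.2-fold lower number from compound 2 to compound 3 (0.07 log units; within the scatter), so compound 2 and compound 3 cannot be told apart. At this place, on a saturated chain carbon bound to an aromatic carbon, a five-membered aromatic ring with 3 hetero atoms gives way to a six-membered aromatic ring of carbon only, and the counts of hydrogen-bond donors and acceptors differ as well, yet this exchange does not separate the two numbers. Nothing measured here gives a reason for this match.

Still open, going by these compounds, is whether a carboxylic acid or a free amine in this place, or a longer chain carrying the benzamido, would move the number beyond the scatter. A single step also cannot show whether benzamido and the triazole ester would match on a different core.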